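Swapping Methyl for Chloro on Two Different Cores

The compounds below may be only part of what the source reports. "The series", "measured", "known", "first", "only" and "open" are said of these compounds alone.

Compound 1 `Cc1ccc(Nc2nc3c(=O)[nH]c(C)nc3s2)cc1` and compound 2 `Cc1nc2sc(Nc3ccc(Cl)cc3)nc2c(=O)[nH]1` share one core and differ in a single group: chloro in place of methyl on an aromatic carbon. In an assay on CHO cells for displacement of a labelled ligand from adenosine receptor A3 (Homo sapiens), read by scintillation counting, with a stated time of 120 min, tested at 1 uM (on this read-out lower numbers stand for less inhibition and higher numbers for more inhibition at the one concentration tested (going by the name of the read-out)), compound 1 gives 47%, and compound 2 gives 49%, so that a number 2 percentage points higher from compound 1 to compound 2 (within the scatter). Compound 3 `CCOc1nc(C)nc2sc(-c3ccc(C)cc3)nc12` is built on another core; the difference between the two cores is not broken down here. In this assay compound 3 gives 5%, the lowest of the three numbers.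

Compound 4 `CCOc1nc(C)nc2sc(-c3ccc(Cl)cc3)nc12` has not yet been measured. It is related to compound 3 by the same change that links compound 1 to compound 2: chloro in place of methyl on an aromatic carbon. The place of the change is described in the same words for both pairs, so the change is the same. Since the earlier step of a number 2 percentage points higher from compound 1 to compound 2 (within the scatter) stayed within the scatter, only a small step is expected in this assay here as well. For compound 4 the expected step is a number 3 percentage points higher from compound 3 to compound 4 (within the scatter), resting on a number 2 percentage points higher from compound 1 to compound 2 (within the scatter). The estimate for compound 4 is 8%, with a range from 0% to 25%.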

Compound 4, a percentage reported as inhibition, at one concentration (the size of the read-out at that concentration, not a potency): 10%
Compound 4: the middle estimate sits 2 percentage points below what was measured; the measured number falls inside the stated range.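

In this assay, putting chloro in place of methyl on the aromatic carbon gives a number 5 percentage points higher from compound 3 to compound 4 (within the scatter). Set beside the earlier result on the other core, the two steps agree: the same change on two cores in this assay, a number 2 percentage points higher (within the scatter) from compound 1 to compound 2 and a number 5 percentage points higher (within the scatter) from compound 3 to compound 4, 3 percentage points apart, within the scatter of two such steps So within these two pairs the swap behaves alike on both cores, and the step from one pair is a fair guide to the step in the other, but both steps lie within the scatter, so a small real effect of the swap cannot be told apart from no effect at all, and two pairs do not make a rule for the whole series.

The compounds shown vary this position only between methyl and chloro, so it stays open what a fluoro, a methoxy or an amine on that aromatic carbon would do. It also stays open whether the step would remain this small on a third core, and, with each number read at a single concentration, how potent any of these compounds is.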